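Nucleoside series: furan-2-yl replacing ethynyl on the core

The source may hold more compounds than are shown below. What is called first, only, known or untested is meant among the compounds shown, and "the series" means these compounds.

The measured set is small. Compound 1 `Nc1nc(N)c2c(-c3ccsc3)cn([C@@H]3O[C@H](CO)[C@@H](O)[C@H]3O)c2n1` returns only a limit in a functional assay on A549 cells (Homo sapiens), read by MTT assay, with a stated time of 72 h (on this read-out higher numbers stand for weaker inhibition and lower numbers for stronger inhibition), > 100000 nM; that value is a boundary of the assay, not a number. Compound 3 `O=c1[nH]cnc2c1c(-c1cc3ccccc3o1)cn2[C@@H]1O[C@H](CO)[C@@H](O)[C@H]1O` likewise returns a limit in this assay, > 20000 nM. Going by the values given here, compound 2 `C#Cc1cn([C@@H]2O[C@H](CO)[C@@H](O)[C@H]2O)c2ncnc(OC)c12` is the one compound with a real number in this assay, 8160 nM, so it stands alone as the only fixed point; the other two entries say only that inhibition was too weak to be resolved, as the limit of > 100000 nM in this assay, at which 1 of the 3 values shown sits, and the limit of > 20000 nM in this assay, at which 1 of the 3 values shown sits, show. Among the compounds with values here, no two measured compounds differ in a single place, so no measured step is available.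

Compound 4 `COc1ncnc2c1c(-c1ccco1)cn2[C@@H]1O[C@H](CO)[C@@H](O)[C@H]1O` keeps the sugar and the methoxy-bearing core of compound 2 and changes one group: furan-2-yl in place of ethynyl on an aromatic carbon. Compounds 1 and 3 both carry an aromatic ring at the same place on their cores and both sit at a limit, while compound 2 with ethynyl gives a number; the cores differ too, so this is a weak hint rather than a rule. The expected step of a 2.5-fold higher number from compound 2 to compound 4 (0.39 log units; beyond the scatter) is therefore toward weaker inhibition, of a size somewhat beyond the scatter. Compound 4 is estimated at 20000 nM in this assay, within a range from 5000 nM to 80000 nM.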

Compound 4, half-maximal inhibitory concentration: 30 nM
For compound 4 the middle estimate is 670-fold (2.82 log units) above the measured one; the whole stated range lies above it.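

In this assay, going by these compounds alone, the replacement of ethynyl by furan-2-yl gives a 270-fold lower number from compound 2 to compound 4 (2.43 log units; beyond the scatter), the first measured step and a large one. This aromatic carbon, two ring bonds from the ring nitrogen, is therefore a place where a single group change on the methoxy-bearing core moves the read-out far beyond the scatter. Within the data shown here, it also shows that a five-membered aromatic ring here does not by itself go with a limit of the assay, which the earlier compounds could not show, as compounds 1 and 3 carry an aromatic ring at this place only on other cores and are known only as limits.

Still open is how far this result depends on furan-2-yl itself, since no other group on this core is shown for comparison, whether an amine, a carboxylic acid or a longer chain at this carbon would keep the low number, and whether furan-2-yl would give a similar step on the cores of compounds 1 and 3. Nothing measured here gives a reason for the size of the step.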